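Swapping the short acyl chain for benzoyl on the shared core

This account rests on a few compounds, and the source may have more. Where it says the series, first, only, none or still open, it means among the compounds named here.

Compound 1 `CCCCCCCCC(=O)N1c2ccccc2CCC1C(=O)Nc1ccccc1C(F)(F)F` gives 4320 nM in a functional assay on PC-3 cells (Homo sapiens) for cytotoxicity, read by sulforhodamine B assay, with a stated time of 72 h; a lower number here means a stronger inhibitor of growth, a higher number a weaker inhibitor of growth.
Compound 2 `CCC(=O)N1c2ccccc2CCC1C(=O)Nc1ccccc1C(F)(F)F` gives > 80000 nM in this assay, which is a limit of the assay and not a number.

Compound 2 therefore stands at the weak end of what has been measured: its result is only a limit, (the limit of > 80000 nM in this assay, at which 1 of the 2 values shown sits). Within the data shown here, the one measured step, an at least 18-fold higher number from compound 1 to compound 2 (1.26 log units; beyond the scatter), shows that cutting the long acyl chain down to propanoyl pushed the number up far beyond the scatter. Compound 3 `O=C(Nc1ccccc1C(F)(F)F)C1CCc2ccccc2N1C(=O)c1ccccc1` differs from compound 2 by phenyl in place of ethyl on a carbonyl carbon. This puts a larger group back onto the carbonyl carbon, though it is not the hexyl-bearing chain of compound 1, so the measured step bears on it only loosely. A lower number than that of compound 2 in this assay seems more likely than not, but the size is uncertain and the result may again be a limit. Compound 3 is expected to give about 25000 nM, with a range from 6000 nM to 100000 nM. This estimate corresponds to an expected step of an at least 3.2-fold lower number from compound 2 to compound 3 (0.50 log units; beyond the scatter), starting from a value that is itself only a limit.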

Compound 3, concentration for 50% growth inhibition: 5560 nM
Estimate against measurement, compound 3: 4.5-fold (0.65 log units) above; measured number below the stated range.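

In this assay, among these compounds, setting phenyl in place of ethyl on this carbonyl carbon gives an at least 14-fold lower number from compound 2 to compound 3 (1.15 log units; beyond the scatter), so a long chain is not the only group here that goes with a measurable inhibition of growth. The result for compound 2 is a limit of the assay and not a number, so this step gives only the smallest size the change can have: the limit of > 80000 nM in this assay, at which 1 of the 3 values shown sits. Setting phenyl in place of octyl on the same carbon gives a 1.3-fold higher number from compound 1 to compound 3 (0.11 log units; within the scatter), so this assay does not separate the two groups, even though one is an aromatic ring and the other an open chain, and of the three groups shown only the ethyl of compound 2 stands apart.

Three groups at one position cannot show whether the size of the group or some other feature of it decides the outcome, and a saturated ring such as cyclohexyl, or a chain of middling length such as butyl, would help to separate those readings. From the compounds shown here alone, it also remains open how a benzoyl group carrying a further substituent, such as methoxy or chlorine, would behave on the shared core.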